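A few compounds are considered here, and "the series" means these few. Any claim that something is new, unique, unknown or untested is made for them only; others in the source may bear on it.

In an ADME assay on the whole organism (Mus musculus, strain C57BL6/N), read by LC-MS, with a stated time of 24 h, at a dose of 50 mg/kg by the oral route (a lower number here means less compound in the circulation, a higher number more compound in the circulation at the dose given), compound 1 (`CNc1cc(C)c(C(N)=O)cn1`) gives 30700 ng.h/mL and compound 3 (`NC(=O)c1cnc2c(c1)CCN2`) gives 29000 ng.h/mL, while compound 2 (`C[C@@H]1Cc2cc(C(N)=O)cnc2N1`) gives 5120 ng.h/mL, the lowest of the three numbers. Compound 4 (`Cc1c(C(N)=O)cnc2c1C[C@@H](C)N2`) departs from compound 2 by one change, methyl in place of hydrogen on an aromatic carbon, ortho to a carbamoyl group. For the measured compounds named here, the one measured step, a 5.7-fold higher number from compound 2 to compound 3 (0.75 log units; beyond the scatter), concerns a saturated ring carbon instead, so it does not gauge this change. Compound 1 also has such a methyl, but its core differs, which makes it only a loose guide. No step beyond the scatter is therefore expected. The estimated step is a 1.4-fold higher number from compound 2 to compound 4 (0.14 log units; within the scatter). For compound 4 the expected value is 7000 ng.h/mL, with an estimated range of 2300 ng.h/mL to 22000 ng.h/mL.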

Compound 4, area under the concentration-time curve: 12100 ng.h/mL
Beside the measured number, compound 4's estimate is 1.7-fold (0.24 log units) below it, within the range that was stated.
By their numbers in this assay, from the lowest: compound 2; then compound 4; then compounds 3 and 1 (each within the scatter of the next).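

In this assay, methyl in place of hydrogen on an aromatic carbon, ortho to a carbamoyl group, gives a 2.4-fold higher number from compound 2 to compound 4 (0.37 log units; beyond the scatter). This shows that this position on the shared core responds to the change, which the step at the saturated ring carbon could not show. Nothing given here accounts for the rise. On these data alone, how an ethyl, a methoxy or an amine at the same carbon would compare remains open. So does whether this methyl would have a similar effect with hydrogen in place of the methyl on the saturated ring carbon.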